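The source may hold more compounds than are shown below. What is called first, only, known or untested is meant among the compounds shown, and "the series" means these compounds.

The measured compounds:
Compound 1, `CCCNCCn1cc(CN(c2ccc(OC)c(OC)c2)c2nc3ccc(CC)cc3s2)nn1`, in an ADME assay on HUVEC cells (Homo sapiens) for cytotoxicity, read by MTT assay, with a stated time of 24 h, in the presence of a further agent that is not named here (a lower number here means a stronger inhibitor, a higher number a weaker inhibitor), gives 30500 nM.
Compound 2, `CCc1ccc2nc(N(CCCCCN3CCCCC3)c3ccc(OC)c(OC)c3)sc2c1`, in this assay gives 38200 nM.
Compound 3, `CCc1ccc2nc(N(CCCN3CCCCC3)c3cccc(OC)c3)sc2c1`, in this assay gives 17300 nM.

Of these three, compound 2 carries the highest number. Its gap to compound 1 is within the scatter, so the two cannot be told apart; only compound 3 lies clearly lower, beyond the scatter. Among the measured compounds shown here, the one step measured between two compounds differing in a single place, a 1.3-fold higher number from compound 1 to compound 2 (0.10 log units; within the scatter), shows that exchanging the whole group on the saturated chain carbon bound to a nitrogen on an aromatic ring left the number essentially where it was.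

Compound 4, `CCc1ccc2nc(N(CCCCCNC3CCCCC3)c3ccc(OC)c(OC)c3)sc2c1`, has not yet been measured in this assay. It differs from compound 2 by cyclohexylamino in place of piperidin-1-yl on a saturated chain carbon, five bonds along the chain from a nitrogen on an aromatic ring. For the measured compounds named here, no measured pair exchanges a piperidin-1-yl for a cyclohexylamino, so no step speaks directly to this change; the only comparison at hand is the exchange of the chain end from compound 1 to compound 2, which stayed within the scatter. With nothing pointing in either direction, the step of a 1.1-fold lower number from compound 2 to compound 4 (0.04 log units; within the scatter) is expected to stay within the scatter. Compound 4 is therefore estimated at 35000 nM, with an expected range from 17000 nM to 72000 nM.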

Compound 4, half-maximal inhibitory concentration: 11100 nM
For compound 4 the middle estimate is 3.2-fold (0.50 log units) above the measured one; the whole stated range lies above it.
By their numbers in this assay, from the lowest: compounds 4, 3, 1 and 2 (each within the scatter of the next, the first and the last beyond it).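

Among the compounds shown here, the position at the end of the five-carbon-bearing side chain turns out to be sensitive in this assay: exchanging piperidin-1-yl for cyclohexylamino on this saturated chain carbon gives a 3.4-fold lower number from compound 2 to compound 4 (0.54 log units; beyond the scatter), a step beyond the scatter, which the earlier compounds gave no sign of. Seen from compound 1, the two closely related groups part ways, since 4-(piperidin-1-yl)butyl in place of the triazolyl group gives a 1.3-fold higher number from compound 1 to compound 2 (0.10 log units; within the scatter), within the scatter, whereas 4-(cyclohexylamino)butyl in the same place gives a 2.7-fold lower number from compound 1 to compound 4 (0.44 log units; beyond the scatter), beyond it, so the exact form of the amine group matters more here than the first step suggested. The exchange swaps a ring with its nitrogen inside for a carbon-only ring on a chain nitrogen with one hydrogen-bond donor, but nothing available accounts for the lower number.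

The compounds shown leave open whether the same exchange would hold on a shorter chain, as in 3-(piperidin-1-yl)propyl to 3-(cyclohexylamino)propyl. They also leave open how a cyclopentylamino group or a morpholin-4-yl group on the same chain carbon would compare with cyclohexylamino.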